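Swapping ethynyl for iodo on a cytotoxic compound

This account rests on a few compounds, and the source may have more. Where it says the series, first, only, none or still open, it means among the compounds named here.

For the measured compounds named here, in a functional assay on NCI-H522 cells (Homo sapiens) for cytotoxicity, with a stated time of 3 days (a higher number here means a weaker inhibitor, a lower number a stronger inhibitor), compound 1 (`C#Cc1nc2ccccc2[se]1`) gives 2170 nM, the only exact number so far. Compound 2 (`C=Cc1csc(Br)n1`) reaches only a limit of the assay, > 40000 nM. Compound 3 (`Cn1cnc2ccccc21`) also stops at a limit, > 40000 nM. Going by the values given here, neither compound differs from compound 1 in just one place, so no measured step offers a guide. Compound 4 (`Ic1nc2ccccc2[se]1`) keeps the core of compound 1 but has iodo in place of ethynyl on an aromatic carbon. A moderate loss of strength in this assay is expected, slightly beyond the usual scatter. The expected change is a 2.3-fold higher number from compound 1 to compound 4 (0.36 log units; beyond the scatter). Compound 4 is estimated at 5000 nM, with an expected range of 1200 nM to 25000 nM.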

Compound 4, half-maximal inhibitory concentration: > 40000 nM
Compound 4: a limit, no number; the forecaster's own chance of this, stated with the estimate: 15%; middle value at least 8.0-fold (0.90 log units) away from the limit.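

In this assay, for the compounds shown here, iodo in place of ethynyl on the shared core gives an at least 18-fold higher number from compound 1 to compound 4 (1.26 log units; beyond the scatter), the first comparison in which only one place changes. The strength of compound 1 therefore depends heavily on what sits at this position, and a single iodine does not stand in for ethynyl. Compound 4 gives only a limit, not a number, so the full size of the loss remains unknown: the limit of > 40000 nM in this assay, at which 3 of the 4 values shown sit.

Going by these compounds, how an amine or a longer chain at this position would compare with ethynyl stays open.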